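Hydroxyl Placement: From Compound 2 to Compound 3

The source may hold more compounds than are shown below. What is called first, only, known or untested is meant among the compounds shown, and "the series" means these compounds.

Measured compounds:
Compound 1: `Oc1ccc(-c2cc(-c3ccccc3C(F)(F)F)cc(-c3cccc(O)c3)n2)cc1`, 3210 nM
Compound 2: `Oc1cccc(-c2cc(-c3ccccc3OC(F)(F)F)cc(-c3ccccc3O)n2)c1`, 2680 nM

In a functional assay on T47D cells (Homo sapiens) for inhibition (a higher number here means a weaker inhibitor, a lower number a stronger inhibitor), compound 1 gives 3210 nM and compound 2 gives 2680 nM. The two numbers lie within the usual scatter of each other, so no order between compound 1 and compound 2 can be read from them, and compound 2 cannot be called the stronger of the pair.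

Compound 3 is `Oc1ccc(-c2cc(-c3ccccc3OC(F)(F)F)cc(-c3cccc(O)c3)n2)cc1`. It differs from compound 2 by 4-hydroxyphenyl in place of 2-hydroxyphenyl on an aromatic carbon, so the hydroxyl moves on one ring while everything else is kept. Among the compounds with values here, no measured pair isolates this change. Compound 1 carries the same 4-hydroxyphenyl and 3-hydroxyphenyl pair and gives 3210 nM, close to compound 2, which gives no sign of a large effect from the hydroxyl position in this series.

Compound 3 is therefore expected to give 3000 nM, range 1200 nM to 7500 nM. The expected step is a 1.1-fold higher number from compound 2 to compound 3 (0.05 log units; within the scatter), nothing beyond the scatter.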

Compound 3, half-maximal inhibitory concentration: 7300 nM
Beside the measured number, compound 3's estimate is 2.4-fold (0.39 log units) below it, within the range that was stated.
By their numbers in this assay, from the lowest: compounds 2 and 1 (each within the scatter of the next); then compound 3.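

In this assay, 4-hydroxyphenyl in place of 2-hydroxyphenyl gives a 2.7-fold higher number from compound 2 to compound 3 (0.44 log units; beyond the scatter), so this position responds to where the hydroxyl sits on the ring, which compounds 1 and 2, differing in more than one place, could not show. The exchange of trifluoromethyl for trifluoromethoxy is now also readable: trifluoromethoxy in place of trifluoromethyl gives a 2.3-fold higher number from compound 1 to compound 3 (0.36 log units; beyond the scatter), with both hydroxyphenyl groups held constant. Each step rests on a single pair, and nothing measured here bears on the reason for either.

As far as these compounds go, whether the change from 2-hydroxyphenyl to 4-hydroxyphenyl has the same size with trifluoromethyl in place of trifluoromethoxy remains open. Also open, from the compounds shown here alone, is how this position would read with an amine or a carboxylic acid in place of the hydroxyl.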